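The source may report more compounds than this note shows. Statements on the series, on what has been measured and on what is new or still open speak of the compounds shown alone.

Measured compounds:
compound 1, `CCC1CCCCN1C(=S)SCCn1c([N+](=O)[O-])cnc1C`, in an ADME assay on HeLa cells (Homo sapiens) for cytotoxicity (on this read-out lower numbers stand for stronger inhibition and higher numbers for weaker inhibition), gives 94 ug/mL.
compound 2, `Cc1ncc([N+](=O)[O-])n1CCSC(=S)N1CCC(OS(C)(=O)=O)CC1`, in this assay gives only a limit, > 1000 ug/mL.

Among the compounds with values here, compound 1 is the one compound here with a number of its own in this assay; the other value is a limit. That limit is the limit of > 1000 ug/mL in this assay, at which 1 of the 2 values shown sits, and it is a limit of the assay, not a number, so compound 2 cannot be placed on the same scale as compound 1 beyond saying that it sits at the limit.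

Compound 3, `Cc1ncc([N+](=O)[O-])n1CCSC(=S)N1CCCCC1C`, has not yet been measured. It differs from compound 1 in one place: hydrogen in place of methyl on a saturated chain carbon bound to a saturated ring carbon. Put another way, the ethyl that sits on the saturated ring carbon of compound 1 becomes a methyl in compound 3, and nothing else changes.

Within the data shown here, no pair of measured compounds differs in one place, so there is no measured step to lean on. A change this small, one carbon on a saturated chain, is expected to move the read-out in this assay by no more than the usual scatter, in no clear direction. The value of compound 3 is therefore estimated at 120 ug/mL, with a range from 50 ug/mL to 300 ug/mL, which means an expected step of a 1.3-fold higher number from compound 1 to compound 3 (0.11 log units; within the scatter).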

Compound 3, half-maximal inhibitory concentration: 170 ug/mL
Estimate against measurement, compound 3: 1.4-fold (0.15 log units) below; the measured number falls inside the stated range.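

Swapping hydrogen for methyl on a saturated chain carbon bound to a saturated ring carbon, which turns the ethyl of compound 1 into the methyl of compound 3, gives in this assay the first step here that can be read between two measured compounds: a 1.8-fold higher number from compound 1 to compound 3 (0.26 log units; within the scatter), so the two compounds cannot be told apart on this read-out. Within the data shown here, at this place, then, the length of the small saturated chain can be cut by one carbon without a change that stands out from repeat measurements, something the earlier compounds could not show, as they differ from each other in more than one place. No measurement shown here bears on why this step is as small as it is.

This single step covers only ethyl and methyl, so it says nothing about how far the same tolerance reaches along a longer chain such as propyl or butyl. Whether an amine or a carboxylic acid on that same chain would leave the read-out just as unmoved also stays open, and the compounds shown give no way to judge it.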